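Aryl Variation on a Shared Core Against Mythimna separata

The compounds below may be only part of what the source reports. "The series", "measured", "known", "first", "only" and "open" are said of these compounds alone.

Measured compounds:
compound 1, `Cc1nnc(COc2cnn(C(C)(C)C)c(=O)c2Cl)o1`, > 299000 nM
compound 2, `CC(C)(C)n1ncc(OCc2nnc(-c3ccc(F)cc3)o2)c(Cl)c1=O`, 5200 nM
compound 3, `CC(C)(C)n1ncc(OCc2nnc(-c3ccccc3F)o2)c(Cl)c1=O`, 16800 nM

Compound 1 reaches only a limit in a functional assay on the whole organism for inhibition, with Mythimna separata as the target, with a stated time of 5 days (a higher number here means that more compound is needed for the effect, a lower number that less compound is needed), not a number, the value being > 299000 nM. Compound 2 gives 5200 nM in this assay. Within the data shown here, compound 3 gives 16800 nM in this assay and so stands highest of the two numbers known; its nearest neighbour is compound 2, with a 3.2-fold higher number from compound 2 to compound 3 (0.51 log units; beyond the scatter). The unmeasured compound 4, `CC(C)(C)n1ncc(OCc2nnc(-c3ccc(Cl)cc3Cl)o2)c(Cl)c1=O`, differs from compound 3 by 2,4-dichlorophenyl in place of 2-fluorophenyl on an aromatic carbon. The measured steps that bear on this are an at least 57-fold lower number from compound 1 to compound 2 (1.75 log units; beyond the scatter) and an at least 17-fold lower number from compound 1 to compound 3 (1.25 log units; beyond the scatter), both large, and the modest step of a 3.2-fold higher number from compound 2 to compound 3 (0.51 log units; beyond the scatter). Since a 2,4-dichlorophenyl carries a halogen in the same ring positions as both compound 2 and compound 3, a modest step downward from compound 3 is expected, roughly a 2.1-fold lower number from compound 3 to compound 4 (0.32 log units; beyond the scatter). Compound 4 is therefore estimated at 8000 nM in this assay, expected to fall between 2000 nM and 40000 nM.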

Compound 4, half-maximal effective concentration: 27800 nM
The estimate for compound 4 lay 3.5-fold (0.54 log units) below the measured number; the range from low to high includes it.
By their numbers in this assay, from the lowest: compound 2; then compounds 3 and 4 (each within the scatter of the next). At a limit, above all of these: compound 1.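

In this assay, putting 2,4-dichlorophenyl in place of 2-fluorophenyl at this position on the five-membered ring gives a 1.7-fold higher number from compound 3 to compound 4 (0.22 log units; within the scatter), so this change does not separate the two compounds. The 4-fluorophenyl group keeps its distance from the new group, with a 5.3-fold higher number from compound 2 to compound 4 (0.73 log units; beyond the scatter), and compound 2 remains the compound needing the least in this set. A third aryl group in place of methyl again gives a large step, an at least 10-fold lower number from compound 1 to compound 4 (1.03 log units; beyond the scatter), and that step rests on a limit for compound 1: the limit of > 299000 nM in this assay, at which 1 of the 4 values shown sits.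

The compounds shown leave open whether a 4-chlorophenyl or a 2-chlorophenyl would sit nearer to compound 2 or to compound 4. They also leave open whether a benzyl group, a longer alkyl chain or an amine at this position could stand in for the aryl ring.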